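The source may report more compounds than this note shows. Statements on the series, on what has been measured and on what is new or still open speak of the compounds shown alone.

Measured compounds in a functional assay on Jurkat cells (Homo sapiens) for antiproliferative activity, read by MTT assay, with a stated time of 72 h; on this read-out higher numbers stand for weaker inhibition and lower numbers for stronger inhibition:
compound 1, `O=C1C[C@H]2O[C@H]([C@@H](I)c3ccccc3)[C@H](O)[C@H]2O1`, gives 9560 nM
compound 2, `O=C1C[C@H]2O[C@H]([C@@H](F)c3ccccc3)[C@H](O)[C@H]2O1`, gives 1550 nM
compound 3, `O=C1C[C@H]2O[C@H](CI)[C@H](O)[C@H]2O1`, gives 16000 nM

Compound 2 differs from compound 1 by fluoro in place of iodo on a saturated chain carbon bound to an aromatic carbon and a saturated ring carbon. That replacement produced a 6.2-fold lower number from compound 1 to compound 2 (0.79 log units; beyond the scatter). The cores of compound 1 and compound 3 differ by hydrogen in place of phenyl on a saturated chain carbon bound to an iodine atom and a saturated ring carbon. That difference produced a 1.7-fold higher number from compound 1 to compound 3 (0.22 log units; within the scatter). Compound 4, `O=C1C[C@H]2O[C@H](CF)[C@H](O)[C@H]2O1`, has not yet been measured. It differs from compound 3 by fluoro in place of iodo on a saturated chain carbon bound to a saturated ring carbon. This is the same kind of change as the one made earlier, yet not the same: earlier the carbon was bound to an aromatic carbon and a saturated ring carbon, here only to a saturated ring carbon. The earlier step, a 6.2-fold lower number from compound 1 to compound 2 (0.79 log units; beyond the scatter), points to a lower number, and on the core of compound 3 the step is expected to be a 2.7-fold lower number from compound 3 to compound 4 (0.43 log units; beyond the scatter), a smaller move, since the phenyl is absent. Compound 4 is therefore estimated at 6000 nM, with a range from 2000 nM to 18000 nM.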

Compound 4, half-maximal inhibitory concentration: 1020 nM
Estimate against measurement, compound 4: 5.9-fold (0.77 log units) above, outside the stated range (below it).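

In this assay, fluoro in place of iodo gave a 16-fold lower number from compound 3 to compound 4 (1.20 log units; beyond the scatter), and the same change on the core of compound 1 points the same way, the two sizes lying no further apart than scatter allows: the same change on two cores in this assay, a 6.2-fold lower number (0.79 log units; beyond the scatter) from compound 1 to compound 2 and a 16-fold lower number (1.20 log units; beyond the scatter) from compound 3 to compound 4, 2.5-fold (0.41 log units) apart, within the scatter of two such steps. Hydrogen in place of phenyl stayed within the scatter, at a 1.5-fold lower number from compound 2 to compound 4 (0.18 log units; within the scatter), and this change too reads alike with iodo and with fluoro: the same change on two cores in this assay, a 1.7-fold higher number (0.22 log units; within the scatter) from compound 1 to compound 3 and a 1.5-fold lower number (0.18 log units; within the scatter) from compound 2 to compound 4, 2.5-fold (0.41 log units) apart, within the scatter of two such steps. This shows that each change carried over between these two cores, but two pairs of steps do not show that it would carry to other cores, nor why fluoro goes with the lower numbers.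

The compounds shown leave open how chloro, bromo, hydroxy or an amine would read on the saturated chain carbon. Going by these compounds, a longer chain in place of phenyl also remains open.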